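A few compounds are considered here, and "the series" means these few. Any claim that something is new, unique, unknown or untested is made for them only; others in the source may bear on it.

Measured so far in an ADME assay on L02 cells (Homo sapiens) for inhibition, read by MTT assay, with a stated time of 48 h, tested at 100 uM; a lower number here means less inhibition, a higher number more inhibition at the concentration tested (going by the name of the read-out):
compound 1, `COc1ccc(OC)c(-c2nsc(=O)o2)c1`: 25.3%
compound 2, `O=c1nc(-c2ccc([N+](=O)[O-])cc2Cl)ss1`: 28.6%

For the measured compounds named here, only two compounds carry numbers, and they stand close together. The gap between compound 1 and compound 2 lies within the usual scatter of this assay, so compound 1 cannot be set apart from compound 2 on what has been measured. Going by the values given here, no pair of measured compounds differs in only one place, so no step size is known from the data themselves.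

Compound 3 `COc1cccc(-c2nsc(=O)o2)c1` is the next compound to be measured in this assay. It comes from compound 1 by the change (hydrogen in place of methoxy on an aromatic carbon). Among the compounds with values here, with no measured step to lean on, the step of a number 0.3 percentage points lower from compound 1 to compound 3 (within the scatter) is expected to be small, with no clear direction, and is not expected to reach beyond the scatter. Compound 3 is therefore estimated at 25%, within a range from 10% to 40%. That expectation rests on compound 1 and its value of 25.3%.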

Compound 3, a percentage reported as inhibition, at one concentration (the size of the read-out at that concentration, not a potency): 15%
Compound 3: middle estimate off by 10 percentage points, on the high side; the range from low to high includes it.
By their numbers in this assay, from the lowest: compound 3; then compounds 1 and 2 (each within the scatter of the next).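

In this assay the step of a number 10.3 percentage points lower from compound 1 to compound 3 (beyond the scatter) is the first change in one place among the compounds shown, and it puts hydrogen in place of methoxy on the aromatic carbon ortho to a group of 6 heavy atoms and para to a methoxy group. It shows that this carbon is not indifferent to what it carries: the number stands higher with methoxy than with hydrogen, by a modest step that lies beyond the scatter. Nothing given here accounts for this step.

From the compounds shown here alone, only methoxy and hydrogen can be compared at this carbon, so how an amine, a carboxylic acid or a longer chain such as butoxy would read there remains open. Going by these compounds, whether the other methoxy group of compound 3 counts in the same way also remains open.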